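The source may hold more compounds than are shown below. What is called first, only, known or untested is meant among the compounds shown, and "the series" means these compounds.

Measured compounds:
Compound 1 `CC(C)(C)c1cc(C(=O)Nc2ccccn2)n(Cc2ccccc2)n1`: in a physicochemical assay for lipophilicity, read by HPLC, at pH 7.4 (a higher number here means a more lipophilic compound, a lower number a more polar compound), compound 1 gives 4.5.
Compound 2 `NCc1csc(NC(=O)c2cccnn2)n1`: in this assay compound 2 gives 0.2.

Compound 1 holds the higher of the two numbers, and compound 2 lies far below it, a gap well beyond the usual scatter. For the measured compounds named here, the two compounds differ in several places at once, so no single step joins them; the pair shows only that the series spans a wide range of the distribution coefficient.

Compound 3 `CC(C)(C)c1cc(C(=O)Nc2nc(CO)cs2)n(Cc2ccccc2)n1` has not yet been measured in this assay. It keeps the core of compound 1 and changes one group: 4-(hydroxymethyl)-1,3-thiazol-2-yl in place of pyridin-2-yl on an amide-type nitrogen. The group that enters brings one hydrogen-bond donor and three hydrogen-bond acceptors, against none and one for the group that leaves, and it carries one more heavy atom.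

A downward move is expected for this change; the estimated step of a number 0.90 log units lower from compound 1 to compound 3 (beyond the scatter) is expected to go beyond the scatter. Compound 3 is accordingly estimated at 3.6, with a likely range from 2.9 to 4.3.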

Compound 3, distribution coefficient: 3.4
Compound 3: the middle estimate sits 0.20 log units above what was measured; the measured number falls inside the stated range.
By their numbers in this assay, from the lowest: compound 2; then compound 3; then compound 1.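

In this assay, 4-(hydroxymethyl)-1,3-thiazol-2-yl in place of pyridin-2-yl on an amide-type nitrogen gives a number 1.10 log units lower from compound 1 to compound 3 (beyond the scatter) and marks this position as one where a single exchange produces a large step. For the compounds shown here, the earlier pair differed in several places at once, so this is the first change that can be tied to one place, with the core of compound 1 kept intact. The exchange alters the ring size, the hetero atoms and the counts of hydrogen-bond donors and acceptors together, and no evidence is available to assign the step to any one of these differences.

As far as these compounds go, the ring exchange and the hydroxymethyl group arrive as one change, so their separate shares of the step remain open, and 1,3-thiazol-2-yl or 4-methyl-1,3-thiazol-2-yl on the same amide-type nitrogen would bear on that split. Also open, from the compounds shown here alone, is how the number would respond at this place to a carboxylic acid or a longer chain in place of the hydroxymethyl group.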